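Methoxy to Methylsulfanyl: an Expected Stronger Effect

The compounds below may be only part of what the source reports. "The series", "measured", "known", "first", "only" and "open" are said of these compounds alone.

Of the compounds shown here, two have been measured. In a functional assay on Caco-2 cells (Homo sapiens), read by fluorescence and BrdU incorporation, with a stated time of 48 h, tested at 25 uM (on this read-out lower numbers stand for a stronger effect and higher numbers for a weaker effect at the one concentration tested), compound 1 `COc1cc(OC)c(C(=O)/C=C/c2ccccc2SC)c(OC)c1` gives 2.2%, and compound 2 `COc1cc(O)c(C(=O)/C=C/c2ccccc2OC)c(OC)c1` gives 37%, the highest of the two numbers and beyond the scatter from compound 1. Compound 3 `COc1cc(O)c(C(=O)/C=C/c2ccccc2SC)c(OC)c1` has not been measured; it differs from compound 2 by methylsulfanyl in place of methoxy on an aromatic carbon. Among the measured compounds shown here, no step between measured compounds is available, so the size is uncertain, but a drop in this assay is expected because compound 1 carrying methylsulfanyl gives 2.2%. For compound 3 the estimate is 12%, between 2% and 35%. This expected change amounts to a number 25 percentage points lower from compound 2 to compound 3 (beyond the scatter).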

Compound 3, a percentage reported as activity, at one concentration (the size of the read-out at that concentration, not a potency): 37%
Beside the measured number, compound 3's estimate is 25 percentage points below it; the whole stated range lies below it.
By their numbers in this assay, from the lowest: compound 1; then compounds 2 and 3 (each within the scatter of the next).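

In this assay, methylsulfanyl in place of methoxy on this aromatic carbon, ortho to a large group, gives no change at the digits printed from compound 2 to compound 3 (within the scatter), so this swap alone leaves the read-out where it was. The large step lies at another place: hydrogen in place of methyl on an oxygen on an aromatic ring gives a number 34.8 percentage points higher from compound 1 to compound 3 (beyond the scatter). Nothing shown here gives a reason for either result.

As far as these compounds go, how an amine or an ethoxy group would read at the same aromatic carbon stays open. Also open, from the compounds shown here alone, is whether the step at that oxygen would be as large with methoxy instead of methylsulfanyl.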